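The source may hold more compounds than are shown below. What is called first, only, known or untested is meant among the compounds shown, and "the series" means these compounds.

Working notes on the series. In an assay on Sf9 cells for inhibition of protein deacetylase HDAC6 (Homo sapiens), read by fluorescence, with stated times of 10 min and 2 h (a lower number here means a stronger inhibitor, a higher number a weaker inhibitor), compound 1 `O=C(NO)c1ccc(CN(CCCCO)C(=O)Nc2ccccc2)cc1` gives 0.87 nM. Compound 2 `CCCCN(C(=O)Nc1cccc(N(C)C)c1)c1ccc(C(=O)NO)cc1` gives 1790 nM in this assay. Compound 3 `CCCCN(Cc1ccc(N(O)C=O)cc1)C(=O)Nc1ccccc1` gives 1030 nM in this assay, the second highest of the three numbers; compound 2 stands nearest, and the two numbers lie within the usual scatter, so no order between compound 2 and compound 3 is drawn, while compound 1 stands furthest, with a much lower number, a gap well beyond the scatter.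

Compound 4 `CCCCN(Cc1ccc(NC(=O)[C@H](C)N)cc1)C(=O)Nc1ccccc1` awaits measurement in this assay. It differs from compound 3 in one place: ((1-aminoethyl)carbonyl)amino in place of formyl(hydroxy)amino on an aromatic carbon. Among the compounds with values here, no measured pair carries this same change, so there is no direct precedent for its size. Working expectation: the step of a 29-fold higher number from compound 3 to compound 4 (1.46 log units; beyond the scatter) is estimated to run towards a higher number, beyond the scatter, and a measurement that returns only a limit is considered a real possibility. Compound 4 is estimated at 30000 nM, with a range from 5000 nM to 200000 nM.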

Compound 4, half-maximal inhibitory concentration: "not active" (no number reported)
Compound 4: no number reported, and the estimate cannot be compared.
By their numbers in this assay, from the lowest: compound 1; then compounds 3 and 2 (each within the scatter of the next).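

Within the data shown here, compound 4 is reported in this assay as not active, with no number, so no step from compound 3 to compound 4 can be read. Nothing measured here bears on this result. The compounds shown leave open how large the effect of replacing formyl(hydroxy)amino with ((1-aminoethyl)carbonyl)amino is.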